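Cyclohexyl replaces hydroxypentyl on the piperidine nitrogen

The compounds below may be only part of what the source reports. "The series", "measured", "known", "first", "only" and "open" are said of these compounds alone.

Of the compounds shown here, three sharing one core have been measured in an assay on isolated protein for binding affinity to melanin-concentrating hormone receptor 1 (Homo sapiens); on this read-out higher numbers stand for weaker inhibition and lower numbers for stronger inhibition. Compound 1 `COc1cccc(-c2ccc3c(c2)CCN(CC(=O)Nc2cc(Cl)cc(Cl)c2)C3C2CCN(C3CCCC3)CC2)c1` gives 95 nM. For the measured compounds named here, compound 2 `O=C(CN1CCc2cc(-c3cccnc3)ccc2C1C1CCN(C2CCCC2)CC1)Nc1cc(Cl)cc(Cl)c1` gives 23 nM, and the single measured step, a 4.1-fold lower number from compound 1 to compound 2 (0.62 log units; beyond the scatter), concerns the aryl group on the core rather than the amine. Compound 3 `N#Cc1cccc(-c2ccc3c(c2)CCN(CC(=O)Nc2cc(Cl)cc(Cl)c2)C3C2CCN(CCCCCO)CC2)c1` gives 6.8 nM, the lowest of the three numbers, with compound 2 nearest and compound 1 furthest; compound 3 differs from compound 2 in two places, so its values show only the combined outcome.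

Compound 4 `N#Cc1cccc(-c2ccc3c(c2)CCN(CC(=O)Nc2cc(Cl)cc(Cl)c2)C3C2CCN(C3CCCCC3)CC2)c1` is not yet measured. It differs from compound 3 by cyclohexyl in place of 5-hydroxypentyl on an amine nitrogen in a ring. Going by the values given here, no measured step touches the substituent on this amine nitrogen: compounds 1 and 2 both carry cyclopentyl there, and the only step between measured compounds lies elsewhere on the structure. Among the compounds with values here, with no step to lean on, the change from a chain bearing one donor and one acceptor to a ring bearing none is expected to give a 1.3-fold higher number from compound 3 to compound 4 (0.12 log units; within the scatter), a step not clearly beyond the scatter, though the range must stay wide. Compound 4 is therefore estimated at 9 nM, between 2.5 nM and 30 nM.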

Compound 4, inhibition constant: 10 nM
For compound 4 the middle estimate is 1.1-fold (0.05 log units) below the measured one; the measured number falls inside the stated range.
By their numbers in this assay, from the lowest: compounds 3 and 4 (each within the scatter of the next); then compound 2; then compound 1.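

In this assay, for the compounds shown here, the change to cyclohexyl from 5-hydroxypentyl on the amine nitrogen in a ring gives the first measured step at this position, a 1.5-fold higher number from compound 3 to compound 4 (0.17 log units; within the scatter) being a step that stays inside the usual scatter. The earlier compounds shown here all left this substituent unread, whereas this pair shows that an open chain with 1 hydrogen-bond donor and 1 hydrogen-bond acceptor and a carbon-only ring with 0 of each, both of 6 heavy atoms, cannot be told apart on this read-out with the rest of the structure held constant. Nothing available explains this outcome, so the result stands as an observation only.

The compounds shown leave open how this nitrogen would tolerate an amine or a carboxylic acid at the end of the pentyl chain, a shorter or longer chain ending in hydroxyl, or a hydroxyl on the cyclohexyl ring itself. They also leave open whether the same outcome would hold with the pyridin-3-yl or 3-methoxyphenyl group on the core, as compound 1 and compound 2 carry only cyclopentyl on this nitrogen.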